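Triazole-linked pyrimidines: moving the chlorine on the benzyl group

The source may hold more compounds than are shown below. What is called first, only, known or untested is meant among the compounds shown, and "the series" means these compounds.

Measured so far:
compound 1 `N#Cc1c(Nc2cccc(C(F)(F)F)c2)nc(SCc2cn(Cc3ccccc3Cl)nn2)nc1-c1ccccc1` – 12600 nM
compound 2 `N#Cc1c(Nc2ccc(F)cc2)nc(SCc2cn(Cc3ccccc3Cl)nn2)nc1-c1ccccc1` – 19900 nM
compound 3 `Cc1ccccc1Nc1nc(SCc2cn(Cc3ccccc3Cl)nn2)nc(-c2ccccc2)c1C#N` – 7950 nM

In a functional assay on MCF7 cells (Homo sapiens) for inhibition, read by MTT assay, with a stated time of 72 h (on this read-out higher numbers stand for weaker inhibition and lower numbers for stronger inhibition), compound 3 gives 7950 nM, the lowest of the three numbers. Going by the values given here, its step from compound 1 is a 1.6-fold lower number from compound 1 to compound 3 (0.20 log units; within the scatter), so the two are not separable; only the step from compound 2 is resolved: a 2.5-fold lower number from compound 2 to compound 3 (0.40 log units; beyond the scatter). The remaining step, a 1.6-fold higher number from compound 1 to compound 2 (0.20 log units; within the scatter), also falls within the scatter. All three measured steps change the aryl group on the ring nitrogen and leave the benzyl group on the triazole untouched.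

Compound 4 `Cc1ccccc1Nc1nc(SCc2cn(Cc3ccc(Cl)cc3)nn2)nc(-c2ccccc2)c1C#N` differs from compound 3 only there: 4-chlorophenyl in place of 2-chlorophenyl on a saturated chain carbon bound to an aromatic nitrogen. Among the compounds with values here, no measured step bears on this part of the molecule, so there is nothing to suggest a direction. On that basis the step from compound 3 to compound 4 in this assay is expected to be small, likely none beyond the scatter: a 1.1-fold higher number from compound 3 to compound 4 (0.03 log units; within the scatter). As far as these compounds go, for compound 4 in this assay the expected value is therefore 8500 nM, with a range from 3000 nM to 24000 nM, the width reflecting that this position is untested.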

Compound 4, half-maximal inhibitory concentration: > 64000 nM
Compound 4: no number, only a limit; the forecaster's own chance of this, stated with the estimate: 5%; middle value at least 7.5-fold (0.87 log units) away from the limit.
By their numbers in this assay, from the lowest: compounds 3, 1 and 2 (each within the scatter of the next, the first and the last beyond it). At a limit, above all of these: compound 4.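

In this assay compound 4 gives > 64000 nM, which is a limit of the assay and not a number. The benzyl group on the triazole is therefore not a silent part of the molecule: going from 2-chlorobenzyl to 4-chlorobenzyl, with the same atoms joined differently, gives an at least 8.0-fold higher number from compound 3 to compound 4 (0.90 log units; beyond the scatter), whereas the largest step among the earlier aryl changes on the ring nitrogen is a 2.5-fold lower number from compound 2 to compound 3 (0.40 log units; beyond the scatter). So the place of the chlorine on this benzyl group matters in this series at least as much as any aryl change shown so far, and the full size of the step cannot be read, as compound 4 sits at the limit: the limit of > 64000 nM in this assay, at which 1 of the 4 values shown sits.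

As far as these compounds go, whether the chlorine in 2-chlorobenzyl favours the activity or the one in 4-chlorobenzyl disfavours it stays open, and an unsubstituted benzyl group or a longer chain such as phenethyl at the same place would help separate the two readings. Going by these compounds alone, it is also open whether the same change carries over to the 3-(trifluoromethyl)phenyl and 4-fluorophenyl compounds, compound 1 and compound 2, since the step is seen only with the 2-methylphenyl group.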